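Thiocarbamate amide series: note on the chloroindoline analogue

This account rests on a few compounds, and the source may have more. Where it says the series, first, only, none or still open, it means among the compounds named here.

Measured so far:
compound 1 `Nc1ccccc1NC(=O)c1ccc(CSC(=S)N2CCN(Cc3ccccn3)CC2)cc1`: 61.4%
compound 2 `CCN(Cc1ccncc1)C(=S)SCc1ccc(C(=O)Nc2ccccc2N)cc1`: 77.7%
compound 3 `Nc1ccccc1NC(=O)c1ccc(CSC(=S)N2CCN(c3ccc(F)cc3)CC2)cc1`: 64.5%

In a functional assay on HeLa cells (Homo sapiens) for antiproliferative activity, read by CCK-8 assay, with a stated time of 72 h, tested at 8 uM (on this read-out lower numbers stand for a weaker effect and higher numbers for a stronger effect at the one concentration tested), compound 2 gives 77.7%, the highest of the three numbers; its nearest neighbour is compound 3 and its furthest compound 1, and both gaps lie beyond the scatter. Compound 4 `Nc1ccccc1NC(=O)c1ccc(CSC(=S)N2CCc3cc(Cl)ccc32)cc1` is not yet measured. It departs from compound 2 as follows: 5-chloro-2,3-dihydro-1H-indol-1-yl in place of ethyl((pyridin-4-yl)methyl)amino on a thiocarbonyl carbon.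

Going by the values given here, only one measured step exists, a number 3.1 percentage points higher from compound 1 to compound 3 (within the scatter). That step swaps a substituent on an amine nitrogen in a ring while the thiocarbonyl carbon keeps the same neighbour, so it speaks to the present change only at a distance. Among the compounds with values here, no measured step replaces the whole amine on the thiocarbonyl carbon. What the numbers do show is that compound 1 and compound 3, which both carry an amine nitrogen in a ring on that carbon, sit below compound 2 by more than the scatter, and compound 4 again places a ring nitrogen there. On that basis a downward step is expected, a number 12.7 percentage points lower from compound 2 to compound 4 (beyond the scatter), taking compound 4 toward the level of compound 1 and compound 3. The estimate for compound 4 is 65%, with a range from 50% to 78%.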

Compound 4, a percentage reported as inhibition, at one concentration (the size of the read-out at that concentration, not a potency): 65.1%
Beside the measured number, compound 4's estimate is 0.1 percentage points below it; the measured number falls inside the stated range.
By their numbers in this assay, from the lowest: compounds 1, 3 and 4 (each within the scatter of the next); then compound 2.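

In this assay, going by these compounds alone, the step of a number 12.6 percentage points lower from compound 2 to compound 4 (beyond the scatter) is the first measured replacement of the whole amine on the thiocarbonyl carbon, and it shows that this position responds to such a change by more than the scatter, whereas the earlier step, made further out on a ring amine nitrogen, stayed within it. The heavy-atom count is the same on both sides of the change, so the step does not come with a change in that count; what differs is the composition: the pyridine ring, with its one hydrogen-bond acceptor, leaves, and a chlorine-bearing fused ring system with no acceptor enters. Among the compounds shown, only compound 2 lacks a ring around the nitrogen on that carbon, and no measurement on hand explains why the change lowers the number.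

The change alters several features at once, so the compounds shown leave open whether the step follows from losing the pyridine nitrogen, from tying the amine nitrogen into a ring, or from the chlorine. Benzyl(ethyl)amino on the thiocarbonyl carbon would test the pyridine nitrogen, and unsubstituted 2,3-dihydro-1H-indol-1-yl would test the chlorine.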